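Working notes: from compound 3 to compound 4

This account rests on a few compounds, and the source may have more. Where it says the series, first, only, none or still open, it means among the compounds named here.

The series shares one core, seen in compound 1 `COc1cc(-c2cc(/C=C/C(=O)c3ccc(N)cc3)[nH]n2)cc(OC)c1OC`, compound 2 `COc1cc(-c2cc(/C=C/C(=O)c3ccc(Cl)c(Cl)c3)[nH]n2)cc(OC)c1OC` and compound 3 `COc1ccc(C(=O)/C=C/c2cc(-c3cc(OC)c(OC)c(OC)c3)n[nH]2)cc1`; the three differ only in the ring on the carbonyl carbon. In a functional assay on SK-MEL-2 cells (Homo sapiens) for cytotoxicity, read by sulforhodamine B assay, with a stated time of 48 h, tested at 100 uM (on this read-out higher numbers stand for a weaker effect at the one concentration tested and lower numbers for a stronger effect), compound 1 gives -85%, compound 2 gives -60% and compound 3 gives -50%. Compound 3 thus stands highest of the three numbers, nearest to compound 2 and furthest from compound 1: the step of a number 35 percentage points higher from compound 1 to compound 3 (beyond the scatter) lies beyond the scatter, whereas a number 10 percentage points higher from compound 2 to compound 3 (within the scatter) stays within it. Compound 4 `COc1cc(-c2cc(/C=C/C(=O)c3ccc(F)c(F)c3)[nH]n2)cc(OC)c1OC` is not yet measured; it differs from compound 3 by 3,4-difluorophenyl in place of 4-methoxyphenyl on a carbonyl carbon. The step bearing most directly on this change is a number 10 percentage points higher from compound 2 to compound 3 (within the scatter), which replaced a 3,4-dichlorophenyl with the 4-methoxyphenyl and stayed within the scatter; the new change runs that exchange back with a 3,4-difluorophenyl. The other steps, a number 25 percentage points higher from compound 1 to compound 2 (beyond the scatter) and a number 35 percentage points higher from compound 1 to compound 3 (beyond the scatter), concern the 4-aminophenyl of compound 1 and do not touch a halogenated ring. The step of a number 8 percentage points lower from compound 3 to compound 4 (within the scatter) is therefore expected to be small, slightly lower but not beyond the scatter. In this assay compound 4 is estimated at -58%, with a range from -80% to -35%.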

Compound 4, a percentage reported as activity, at one concentration (the size of the read-out at that concentration, not a potency): -64%
The estimate for compound 4 lay 6 percentage points above the measured number; measured number inside the range.
By their numbers in this assay, from the lowest: compound 1; then compounds 4, 2 and 3 (each within the scatter of the next, the first and the last beyond it).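

In this assay, going by these compounds alone, the 3,4-difluorophenyl on the carbonyl carbon gives a number 14 percentage points lower from compound 3 to compound 4 (beyond the scatter), the first step beyond the scatter against the 4-methoxyphenyl at this position, since the 3,4-dichlorophenyl stayed within it. The change between the two halogenated rings, a number 4 percentage points lower from compound 2 to compound 4 (within the scatter), stays within the scatter, so fluorine and chlorine at this position cannot be told apart here, while a number 21 percentage points higher from compound 1 to compound 4 (beyond the scatter) leaves the 4-aminophenyl of compound 1 apart from the 3,4-difluorophenyl as it stood apart from the 3,4-dichlorophenyl. No measurement at hand gives a reason for these differences.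

From the compounds shown here alone, whether a ring with a single fluorine behaves like the 3,4-difluorophenyl remains open. Also open, going by these compounds, is whether a dimethylamino group or a carboxylic acid on that ring would keep the level of compound 1 in this assay.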